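A few compounds are considered here, and "the series" means these few. Any claim that something is new, unique, unknown or untested is made for them only; others in the source may bear on it.

Compound 2 `COc1cc2c(cc1OC)C(CC(=O)NC(C)C)CC2` gives 37% in a functional assay on the whole organism (strain Wistar) for inhibition, with Rattus norvegicus as the target, read by paw edema, with stated times of 60 min and 2 h, at a dose of 100 mg/kg by the oral route (on this read-out higher numbers stand for more inhibition at the one dose given (going by the name of the read-out) and lower numbers for less inhibition), and compound 1 `CCCNC(=O)CC1CCc2cc(OC)c(OC)cc21` gives 28% in this assay, the two lying within the scatter of each other. Among the measured compounds shown here, the one step between them, a number 9 percentage points higher from compound 1 to compound 2 (within the scatter), came with isopropyl in place of propyl on an amide-type nitrogen. Compound 3 `CCCCCCNC(=O)CC1CCc2cc(OC)c(OC)cc21` differs from compound 2 by hexyl in place of isopropyl on an amide-type nitrogen. For the measured compounds named here, that earlier step is the only one bearing on this change, and it stayed within the scatter, so no shift beyond the scatter is expected in this assay. The step of a number 2 percentage points lower from compound 2 to compound 3 (within the scatter) is therefore expected. Compound 3 is estimated at 35%, between 15% and 55%.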

Compound 3, a percentage reported as inhibition, in the whole organism at one dose (the size of the read-out at that dose, not a potency): 41.5%
Estimate against measurement, compound 3: 6.5 percentage points below, within the range that was stated.
By their numbers in this assay, from the lowest: compounds 1, 2 and 3 (each within the scatter of the next, the first and the last beyond it).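

In this assay the amide-type nitrogen carries hexyl as well as isopropyl, with a number 4.5 percentage points higher from compound 2 to compound 3 (within the scatter) as the step between them. Going from propyl to hexyl gives a number 13.5 percentage points higher from compound 1 to compound 3 (beyond the scatter) and is the only step here to pass the scatter, so chain length on this nitrogen can matter, though the effect is modest and rests on a single pair. Nothing measured here accounts for either step.

From the compounds shown here alone, whether a longer chain such as octyl would go further remains open. So does whether a benzyl group or a chain ending in an amine or a carboxylic acid would be accepted on this nitrogen.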